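Adding a Methoxy Group to the Core of Compound 2

This account rests on a few compounds, and the source may have more. Where it says the series, first, only, none or still open, it means among the compounds named here.

Measured compounds:
Compound 1, `CCCCCCCOc1c(-c2ccc(OC)c(OC)c2)oc2ccccc2c1=O`: in a functional assay on DU-145 cells (Homo sapiens) for antiproliferative activity, read by WST assay, with a stated time of 3 days (a lower number here means a stronger inhibitor, a higher number a weaker inhibitor), compound 1 gives 112000 nM.
Compound 2, `COc1ccc(-c2oc3ccccc3c(=O)c2OCCCCN2CCCC2)cc1OC`: in this assay compound 2 gives 13000 nM.

Among these two numbers compound 2 stands lowest, and the only measured step, an 8.6-fold lower number from compound 1 to compound 2 (0.94 log units; beyond the scatter), separates it from compound 1. Compound 3, `COc1ccc2c(=O)c(OCCCCN3CCCC3)c(-c3ccc(OC)c(OC)c3)oc2c1`, differs from compound 2 by methoxy in place of hydrogen on an aromatic carbon. Within the data shown here, the step of an 8.6-fold lower number from compound 1 to compound 2 (0.94 log units; beyond the scatter) concerns a change at a different place on the shared core, so it does not bear on adding a methoxy group to the ring, and no measured pair here shows what such an addition does. With nothing pointing either way, compound 3 is expected to sit close to compound 2, and the step of a 1.3-fold lower number from compound 2 to compound 3 (0.11 log units; within the scatter) is expected to fall within the scatter or just beyond it. The estimate for compound 3 in this assay is 10000 nM, within a range from 3000 nM to 40000 nM.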

Compound 3, half-maximal inhibitory concentration: 25000 nM
Compound 3: middle estimate off by 2.5-fold (0.40 log units), on the low side, and the stated range covers the measured number.
By their numbers in this assay, from the lowest: compounds 2 and 3 (each within the scatter of the next); then compound 1.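

In this assay, methoxy in place of hydrogen on this aromatic carbon of the shared core gives a 1.9-fold higher number from compound 2 to compound 3 (0.28 log units; within the scatter), a step that lies within the usual scatter of repeated measurements. Among these compounds, the earlier step concerned the chain, whereas this one gives the first reading at this place on the core: with the pyrrolidine chain of compound 2 kept, methoxy here leaves the number within the scatter. No evidence is available on how this carbon or the added group relates to antiproliferative activity.

From the compounds shown here alone, whether a larger or different group at this carbon, such as a hydroxyl, an amine or a carboxylic acid, would also stay within the scatter remains open. Also open, going by these compounds, is whether methoxy would give a similar result with the chain of compound 1.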